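Lengthening the chain from compound 2 to compound 3

The source may hold more compounds than are shown below. What is called first, only, known or untested is meant among the compounds shown, and "the series" means these compounds.

Among the measured compounds shown here, in a functional assay on MCF7 cells (Homo sapiens) for antiproliferative activity, read by MTT assay, with a stated time of 72 h (a lower number here means a stronger inhibitor, a higher number a weaker inhibitor), compound 1 `CC(=O)NNC(=O)c1csc2ncc(-c3ccc(C)cc3)n12` gives 57300 nM and compound 2 `CCC(=O)NNC(=O)c1csc2ncc(-c3ccc(C)cc3)n12` gives 5190 nM as the lower of the only two numbers so far. For the measured compounds named here, the one measured step, an 11-fold lower number from compound 1 to compound 2 (1.04 log units; beyond the scatter) for methyl in place of hydrogen on a saturated chain carbon bound to a carbonyl carbon, is large and beyond the scatter.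

Compound 3 `CCCC(=O)NNC(=O)c1csc2ncc(-c3ccc(C)cc3)n12` differs from compound 2 by methyl in place of hydrogen on a saturated chain carbon, two bonds along the chain from a carbonyl carbon, which turns ethyl into propyl. Going by the values given here, only that one step bears on this change, and it lies at a different place on the chain, so its size need not carry over. Resting on an 11-fold lower number from compound 1 to compound 2 (1.04 log units; beyond the scatter) alone, compound 3 is expected to move in the same direction, by a smaller amount. The estimated change is a 1.7-fold lower number from compound 2 to compound 3 (0.24 log units; within the scatter) and remains tentative. In this assay compound 3 is expected at 3000 nM with a range of 1000 nM to 9000 nM for now.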

Compound 3, half-maximal inhibitory concentration: 41700 nM
Compound 3: the middle estimate sits 14-fold (1.14 log units) below what was measured; measured number above the stated range.
By their numbers in this assay, from the lowest: compound 2; then compounds 3 and 1 (each within the scatter of the next).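

In this assay the effect of adding carbon to this chain does not continue in one direction: an 11-fold lower number from compound 1 to compound 2 (1.04 log units; beyond the scatter) for methyl on a saturated chain carbon bound to a carbonyl carbon, whereas an 8.0-fold higher number from compound 2 to compound 3 (0.90 log units; beyond the scatter) for methyl on a saturated chain carbon, two bonds along the chain from a carbonyl carbon. Read as a single change, the whole lengthening of the chain gives a 1.4-fold lower number from compound 1 to compound 3 (0.14 log units; within the scatter), so compound 1 and compound 3 lie within the scatter of each other, and compound 2 alone stands apart, with steps beyond the scatter to both. Nothing available here accounts for this reversal along the chain.

Open, going by these compounds, is whether a longer chain stays near compound 3 or shifts the number again, and whether a cyclopropyl group, an amine or a carboxylic acid in place of the ethyl of compound 3 would keep any of the level seen for compound 2. Also open is whether the same order among these chains holds when the shared core carries a group other than the one present in all three compounds.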